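The source may report more compounds than this note shows. Statements on the series, on what has been measured and on what is new or still open speak of the compounds shown alone.

Among the measured compounds shown here, compound 2, `O=c1ccoc2cc(OCc3cn(Cc4ccc(Br)cc4)nn3)ccc12`, gives 96400 nM in a functional assay on QGY7701 cells (Homo sapiens) for cytotoxicity, read by MTT assay, with a stated time of 48 h (on this read-out higher numbers stand for weaker inhibition and lower numbers for stronger inhibition), the highest of the two numbers so far; the nearest is compound 1, `O=c1ccoc2cc(OCc3cn(Cc4cccc(Cl)c4)nn3)ccc12`, which in this assay gives 28400 nM. For the measured compounds named here, the only measured step is a 3.4-fold higher number from compound 1 to compound 2 (0.53 log units; beyond the scatter). Compound 3, `N#Cc1ccc(Cn2cc(COc3ccc4c(=O)ccoc4c3)nn2)cc1`, differs from compound 2 by cyano in place of bromo on an aromatic carbon. Going by the values given here, no measured step bears on a halogen-to-cyano exchange, so nothing beyond the scatter is expected, and compound 3 is estimated at 70000 nM, within 20000 nM to 250000 nM, a step of a 1.4-fold lower number from compound 2 to compound 3 (0.14 log units; within the scatter).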

Compound 3, half-maximal inhibitory concentration: > 100000 nM
Compound 3: a limit, no number; the forecaster's own chance of this, stated with the estimate: 20%; middle value at least 1.4-fold (0.15 log units) from the limit.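

In this assay compound 3 gives a limit and not a number: the limit of > 100000 nM in this assay, at which 1 of the 3 values shown sits. The exchange of bromo for cyano can be read only as an at least 1.0-fold higher number from compound 2 to compound 3 (0.01 log units; that floor lies within the scatter), a floor that fixes no order. The change from the 3-chlorophenyl group reads as an at least 3.5-fold higher number from compound 1 to compound 3 (0.54 log units; beyond the scatter), so cyano, like bromo, stays beyond the scatter on the higher side at this place on the aromatic carbon. From the compounds shown here alone, how far the true value of compound 3 lies past its limit stays open. Going by these compounds, it is also open whether an amine or a carboxylic acid on this aromatic carbon would bring the number down.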